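The source may report more compounds than this note shows. Statements on the series, on what has been measured and on what is new or still open speak of the compounds shown alone.

Measured in a functional assay on Bel-7402 cells (Homo sapiens) for antiproliferative activity, read by MTT assay, with a stated time of 72 h; on this read-out higher numbers stand for weaker inhibition and lower numbers for stronger inhibition:
Compound 1 `COc1cccc(CNCc2c(C(=O)O)n(Cc3ccc(O)cc3)c3cc(C(C)C)ccc23)c1`: 7080 nM
Compound 2 `COc1cccc(CNCc2c(C(=O)O)n(Cc3ccc(O)cc3)c3ccccc23)c1`: > 50000 nM (a limit of the assay, not a number)

Within the data shown here, compound 1 holds the only actual number in this assay, so it cannot be ranked against a second number. Compound 3 `COc1cccc(CNCc2c(C(=O)O)n(Cc3ccccc3F)c3cc(C(C)C)ccc23)c1` keeps the core of compound 1 and changes one group: 2-fluorophenyl in place of 4-hydroxyphenyl on a saturated chain carbon bound to an aromatic nitrogen. Among the measured compounds shown here, the only measured step, an at least 7.0-fold higher number from compound 1 to compound 2 (0.84 log units; beyond the scatter), lies beyond the scatter, but it concerns the isopropyl group, which compound 3 retains. For the measured compounds named here, no measured step touches the 4-hydroxybenzyl group, so neither direction is favoured, and no change beyond the scatter is expected. The expected step is a 1.2-fold lower number from compound 1 to compound 3 (0.07 log units; within the scatter). The estimate for compound 3 is 6000 nM, with an expected range from 2000 nM to 20000 nM.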

Compound 3, half-maximal inhibitory concentration: 5590 nM
Compound 3: the middle estimate sits 1.1-fold (0.03 log units) above what was measured; the range from low to high includes it.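

In this assay, among these compounds, the swap of 4-hydroxybenzyl for 2-fluorobenzyl gives a 1.3-fold lower number from compound 1 to compound 3 (0.10 log units; within the scatter), the first reading of a change at this place, and it lies within the scatter. The 4-hydroxyphenyl group, with its hydrogen-bond donor and acceptor, can therefore give way to 2-fluorophenyl, which has neither, without a change beyond the scatter, so on these two compounds neither the hydroxyl nor the fluorine sets the activity apart. Nothing measured here bears on why the two groups read alike.

From the compounds shown here alone, whether an unsubstituted benzyl, or a benzyl carrying an amine or a carboxylic acid, would read the same remains open, as does whether any group here could bring the number beyond the scatter in either direction. Also open, going by these compounds, is whether 2-fluorobenzyl would hold its reading with hydrogen in place of isopropyl.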